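Chloro in place of hydrogen on the shared core

The source may hold more compounds than are shown below. What is called first, only, known or untested is meant among the compounds shown, and "the series" means these compounds.

In a functional assay on A549 cells (Homo sapiens) for inhibition, read by sulforhodamine B assay, with a stated time of 48 h, tested at 100 uM (on this read-out higher numbers stand for more inhibition of growth at the one concentration tested and lower numbers for less inhibition of growth), compound 1 `O=c1c(C(=S)Nc2ccccc2)coc2ccccc12` gives 79%. Compound 2 `O=c1c(C2N=C(c3ccccc3)SS2)coc2ccccc12` gives 42% in this assay, the lowest of the two numbers; the nearest, compound 1, stands higher by a margin beyond the scatter. For the measured compounds named here, no pair of measured compounds differs in one place, so nothing is known yet of single-group steps. Compound 3 `O=c1c(C2N=C(c3ccccc3)SS2)coc2cc(Cl)ccc12` differs from compound 2 in one place: chloro in place of hydrogen on an aromatic carbon, on an aromatic carbon of a six-membered aromatic ring of carbon only, part of a fused system of two rings. Going by the values given here, with no measured step of this kind at hand, a small step in this assay is expected, either upward or none beyond the scatter. For compound 3 the expected value in this assay is 48%, in the range 25% to 70%. The expected step of a number 6 percentage points higher from compound 2 to compound 3 (within the scatter) thus lies within the scatter.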

Compound 3, percent growth inhibition at one concentration: 76%
Estimate against measurement, compound 3: 28 percentage points below; the whole stated range lies below it.
By their numbers in this assay, from the lowest: compound 2; then compounds 3 and 1 (each within the scatter of the next).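

Chloro in place of hydrogen on an aromatic carbon gives a number 34 percentage points higher from compound 2 to compound 3 (beyond the scatter) in this assay, the first single-group step read in this series, and a large one. This position, meta to a fused ring and para to a fused ring, therefore responds strongly to a change of a single heavy atom, at least with the substituent carried by compound 2 and compound 3. No measurement on hand accounts for the size of this step.

Open, as far as these compounds go, is whether the step belongs to chloro itself or would also follow from fluoro, methyl, methoxy or an amine on the same aromatic carbon. Also open, from the compounds shown here alone, is whether chloro at this place would give a comparable step on compound 1, and how other aromatic carbons of the same ring respond.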